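The compounds below may be only part of what the source reports. "The series", "measured", "known", "first", "only" and "open" are said of these compounds alone.

Compound 1, `COc1cccc(C(=O)N2CCC(=CC(=O)N[C@@H]3CCN(Cc4ccc5cc(F)ccc5c4)C3)CC2)c1O`, in an in vitro ADME assay on microsomes from liver (Homo sapiens) for metabolic stability (a higher number here means faster removal of the compound, a lower number slower removal), gives 162 mL/min/kg.
Compound 2, `O=C(C=C1CCN(C(=O)c2cccc(F)c2)CC1)N[C@@H]1CCN(Cc2ccc3cc(F)ccc3c2)C1`, gives 459 mL/min/kg.
Compound 3, `COc1cccc(O)c1C(=O)N1CCC(=CC(=O)N[C@@H]2CCN(Cc3ccc4cc(F)ccc4c3)C2)CC1`, gives 192 mL/min/kg.

Of these three numbers, compound 1 has the lowest. The nearest of the others lies at a 1.2-fold higher number from compound 1 to compound 3 (0.07 log units; within the scatter), a gap that cannot be told apart from the scatter of repeat measurements; the furthest lies at a 2.8-fold higher number from compound 1 to compound 2 (0.45 log units; beyond the scatter), a gap that is real though modest.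

Compound 4, `O=C(C=C1CCN(C(=O)c2ccccc2O)CC1)N[C@@H]1CCN(Cc2ccc3cc(F)ccc3c2)C1`, differs from compound 1 in one place: hydrogen in place of methoxy on an aromatic carbon. Among the measured compounds shown here, no measured step makes exactly this change, but two come close. a 2.8-fold higher number from compound 1 to compound 2 (0.45 log units; beyond the scatter) came from swapping the whole 2-hydroxy-3-methoxyphenyl for 3-fluorophenyl, so the methoxy left together with the hydroxy. a 1.2-fold higher number from compound 1 to compound 3 (0.07 log units; within the scatter) came from keeping the methoxy but moving it, to give 2-hydroxy-6-methoxyphenyl. Taken together, these two steps suggest that taking away the methoxy alone, with the hydroxy kept, should raise the number somewhat, but by less than the full swap did, and perhaps only at the edge of the scatter. Compound 4 is therefore expected to show a 1.4-fold higher number from compound 1 to compound 4 (0.15 log units; within the scatter), with an estimated value of 230 mL/min/kg and a likely range from 130 mL/min/kg to 400 mL/min/kg.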

Compound 4, clearance: < 64 mL/min/kg
Compound 4: only a limit was reported; the forecaster's own chance of this, stated with the estimate: 2%; middle value at least 3.5-fold (0.55 log units) away from the limit.
By their numbers in this assay, from the lowest: compounds 1 and 3 (each within the scatter of the next); then compound 2. At a limit, below all of these: compound 4.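

In this assay, compound 4 carries a limit rather than a number: the limit of < 64 mL/min/kg in this assay, at which 1 of the 4 values shown sits. Replacing the methoxy with hydrogen while keeping the hydroxy gives an at least 2.5-fold lower number from compound 1 to compound 4 (0.40 log units; beyond the scatter), and the same change starting from the other arrangement of the ring gives an at least 3.0-fold lower number from compound 3 to compound 4 (0.47 log units; beyond the scatter), so removing this group matters more than moving it, a move that gave only a 1.2-fold higher number from compound 1 to compound 3 (0.07 log units; within the scatter). The earlier compounds shown here showed hydroxy-bearing rings giving similar numbers, yet the 2-hydroxyphenyl ring of compound 4 stands well apart from both of them, and its step from the 3-fluorophenyl ring, an at least 7.1-fold lower number from compound 2 to compound 4 (0.85 log units; beyond the scatter), is also clearly larger than a 2.4-fold lower number from compound 2 to compound 3 (0.38 log units; beyond the scatter).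

Going by these compounds, what stays open is whether any group at this place raises the number or the methoxy is special, which a methyl, an ethoxy or a chlorine on the same aromatic carbon could help to tell. An unsubstituted phenyl or a 2-methoxyphenyl on the same carbonyl would show how much of the low limit of compound 4 depends on the hydroxy itself.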